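The compounds below may be only part of what the source reports. "The series", "measured", "known", "first", "only" and "open" are said of these compounds alone.

Measured in a functional assay on SGC-7901 cells (Homo sapiens) for antiproliferative activity, read by MTT assay, with a stated time of 48 h; a lower number here means a stronger inhibitor, a higher number a weaker inhibitor:
- compound 1 `Cc1ccc(-c2nnc(SCc3ccc(Cl)nc3)o2)cc1`: 3.62 ug/mL
- compound 2 `COc1ccccc1-c1nnc(SCc2ccc(Cl)nc2)o1`: 8.2 ug/mL
- compound 3 `Fc1ccccc1-c1nnc(SCc2ccc(Cl)nc2)o1`: 9.12 ug/mL

Compound 3 stands at the upper end of these numbers, together with compound 2, as a 1.1-fold higher number from compound 2 to compound 3 (0.05 log units; within the scatter) shows. Against the 4-methylphenyl compound the gap is real: a 2.5-fold higher number from compound 1 to compound 3 (0.40 log units; beyond the scatter). Compound 4 `Oc1ccc(-c2nnc(SCc3ccc(Cl)nc3)o2)cc1` is still unmeasured and carries 4-hydroxyphenyl in place of 2-fluorophenyl on an aromatic carbon. Within the data shown here, no hydroxy compound has been measured, so the nearest guide is compound 1, which also bears a 4-substituted phenyl and gives 3.62 ug/mL. A modest move toward a lower number is therefore expected, a 1.7-fold lower number from compound 3 to compound 4 (0.22 log units; within the scatter). The estimate for compound 4 is 5.5 ug/mL, with an expected range of 2.5 ug/mL to 12 ug/mL.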

Compound 4, half-maximal inhibitory concentration: > 20 ug/mL
Compound 4: no number, only a limit; the forecaster's own chance of this, stated with the estimate: 3%; at least 3.6-fold (0.56 log units) between middle value and limit.
By their numbers in this assay, from the lowest: compound 1; then compounds 2 and 3 (each within the scatter of the next). At a limit, above all of these: compound 4.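

In this assay compound 4 gives no number, only a limit: the limit of > 20 ug/mL in this assay, at which 1 of the 4 values shown sits.

Setting 4-hydroxyphenyl in place of 2-fluorophenyl gives an at least 2.1-fold higher number from compound 3 to compound 4 (0.34 log units; beyond the scatter), so this position can carry a group that lies further up than the 2-fluorophenyl and 2-methoxyphenyl compounds, which sit within the scatter of each other. Hydroxy in place of methyl gives an at least 5.5-fold higher number from compound 1 to compound 4 (0.74 log units; beyond the scatter), so what the phenyl carries matters, not only where it sits.

Going by these compounds, how far compound 4 lies past its limit stays open. So does whether an amine or a carboxylic acid in that place would follow hydroxy or methyl.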